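This account rests on a few compounds, and the source may have more. Where it says the series, first, only, none or still open, it means among the compounds named here.

Compound 2 `NS(=O)(=O)c1ccc(N2C(=O)CC(C3CCCCCC3=O)C2=O)cc1` carries a seven-membered ketone ring on the shared core, and in an assay on Sf21 cells for inhibition of cytochrome c oxidase subunit 2 (Homo sapiens), read by spectrophotometry, with a stated time of 5 min (on this read-out lower numbers stand for stronger inhibition and higher numbers for weaker inhibition), compound 2 gives 20700 nM. Its near analogue compound 1 `NS(=O)(=O)c1ccc(N2C(=O)CC(C3CCCCC3=O)C2=O)cc1` has the six-membered ketone ring, and compound 1 gives 21300 nM; the step of a 1.0-fold lower number from compound 1 to compound 2 (0.01 log units; within the scatter) shows that the ring size makes no difference here. Compound 3 `CC(=O)CC1CC(=O)N(c2ccccc2)C1=O` has an open-chain ketone and no sulfamoyl group, and compound 3 gives 63900 nM. Compound 2 thus has the lowest number of the three, although compound 1 lies within the scatter of it, while compound 3 stands well apart.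

Compound 4 `O=C1CCCCCC1C1CC(=O)N(c2ccccc2)C1=O` differs from compound 2 by hydrogen in place of sulfamoyl on an aromatic carbon. Among the compounds with values here, no measured step isolates this change: the single step concerns only the ketone ring and was flat. Within the data shown here, the only guide is that compound 3, which also lacks sulfamoyl, gives a higher number than compound 2, but it differs in a second place as well. A modest rise is therefore expected for compound 4, as a 1.9-fold higher number from compound 2 to compound 4 (0.29 log units; within the scatter), with wide uncertainty. The estimate for compound 4 is 40000 nM, between 15000 nM and 110000 nM.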

Compound 4, half-maximal inhibitory concentration: 39500 nM
For compound 4 the middle estimate is 1.0-fold (0.01 log units) above the measured one; the measured number falls inside the stated range.
By their numbers in this assay, from the lowest: compounds 2, 1, 4 and 3 (each within the scatter of the next, the first and the last beyond it).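

Within the data shown here, the step of a 1.9-fold higher number from compound 2 to compound 4 (0.28 log units; within the scatter) is the first direct reading of the sulfamoyl position, since the earlier step concerned only the ketone ring. In this assay, hydrogen in place of sulfamoyl on this aromatic carbon, para to a large group, stays within the scatter, so the sulfamoyl group is not shown to matter for the number when the seven-membered ketone ring is present. No supporting measurement bears on this result.

The compounds shown leave open whether a carboxylic acid or an amine on this aromatic carbon would move the number beyond the scatter of compound 2. They also leave open whether hydrogen in place of sulfamoyl would read the same on compound 1, with its six-membered ketone ring.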